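Benzofuran ketones: methyl-to-hydrogen step on an aryl oxygen

This account rests on a few compounds, and the source may have more. Where it says the series, first, only, none or still open, it means among the compounds named here.

Working notes on four related compounds. Compound 1 `CCc1cc2c(C(=O)c3ccc(OC)cc3)c(OC)ccc2o1` carries two methyl groups on oxygen atoms; in an assay for inhibition of solute carrier family 22 member 12 (Homo sapiens), read by scintillation counting, with a stated time of 60 min (a lower number here means a stronger inhibitor, a higher number a weaker inhibitor), compound 1 gives "not determined" (no result reported), so no number was reported for it. Compound 2 `CCc1oc2ccc(OC)cc2c1C(=O)c1ccc(O)cc1` is built on a different core; the difference between the two cores is not broken down here. In this assay compound 2 gives 2460 nM. Compound 3 `CCc1oc2ccc(O)cc2c1C(=O)c1ccc(O)cc1` follows from compound 2 by hydrogen in place of methyl on an oxygen on an aromatic ring. In this assay compound 3 gives 2490 nM, so the step is a 1.0-fold higher number from compound 2 to compound 3 (0.01 log units; within the scatter).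

Compound 4 `CCc1cc2c(C(=O)c3ccc(O)cc3)c(OC)ccc2o1` has not yet been measured in this assay. It follows from compound 1 by hydrogen in place of methyl on an oxygen on an aromatic ring. The place of this change reads the same, word for word, as the place of the change from compound 2 to compound 3, so it is taken as the same change made on a second core. Among the compounds with values here, with the two cores differing in a way not broken down here, the step measured on the core of compound 2 is the only guide to its size.

Within the data shown here, on the core of compound 1 the same change is expected to give a step of about the same size as the one from compound 2 to compound 3, because that step, a 1.0-fold higher number from compound 2 to compound 3 (0.01 log units; within the scatter), lay within the scatter. Compound 1 has no number, so nothing anchors the absolute level of compound 4 on its own core. Among the measured compounds shown here, the only measured numbers in the set, those of compound 2 and compound 3, are taken as the nearest available guide to the level of compound 4. Compound 4 is therefore estimated at 3000 nM, with a wide range from 600 nM to 15000 nM, the width reflecting the untested core.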

Compound 4, half-maximal inhibitory concentration: 6680 nM
The estimate for compound 4 lay 2.2-fold (0.35 log units) below the measured number; measured number inside the range.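

In this assay, within the data shown here, compound 1 gives "not determined" (no result reported), so the step from compound 1 to compound 4 cannot be read and the new result adds no step. Nothing shown bears on the value of compound 4. The compounds shown leave open whether methoxy to hydroxy on the core of compound 1 gives a step of the size seen on the core of compound 2.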